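The source may report more compounds than this note shows. Statements on the series, on what has been measured and on what is new or still open speak of the compounds shown alone.

Measured compounds:
compound 1 `c1ccc(-c2cn3ccnc3c(-c3ccc4ncn(C5CCCCC5)c4c3)n2)cc1` — 59.5%
compound 2 `O=Cc1ccc(-c2cn3ccnc3c(-c3ccc4ncn(C5CCCCC5)c4c3)n2)cc1` — 92.6%
compound 3 `c1cn2cc(-c3ccsc3)nc(-c3ccc4ncn(C5CCCCC5)c4c3)c2n1` — 13.4%

In a functional assay on HCT-116 cells (Homo sapiens) for inhibition, read by sulforhodamine B assay, with a stated time of 48 h, tested at 10 uM (on this read-out higher numbers stand for more inhibition at the one concentration tested (going by the name of the read-out) and lower numbers for less inhibition), compound 3 gives 13.4%, the lowest of the three numbers. The step of a number 46.1 percentage points lower from compound 1 to compound 3 (beyond the scatter) and the step of a number 79.2 percentage points lower from compound 2 to compound 3 (beyond the scatter) both point the same way: swapping a phenyl or a 4-formylphenyl for the thiophen-3-yl group costs a great deal of inhibition on the shared core.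

Compound 4 `COc1ccccc1-c1cn2ccnc2c(-c2ccc3ncn(C4CCCCC4)c3c2)n1` reverses that swap in kind: 2-methoxyphenyl in place of thiophen-3-yl on an aromatic carbon. A six-membered ring of carbon returns, now carrying a methoxy group. The step of a number 46.1 percentage points lower from compound 1 to compound 3 (beyond the scatter) bears on this most directly and was large, so going back to a phenyl-type ring should recover much of that loss. For the measured compounds named here, the step of a number 33.1 percentage points higher from compound 1 to compound 2 (beyond the scatter) shows that a substituent on that ring can shift the number strongly, but no measured compound carries a methoxy, so its own effect is unknown. Compound 4 is therefore expected to rise by about a number 36.6 percentage points higher from compound 3 to compound 4 (beyond the scatter), landing near 50%, within a range of 20% to 80%.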

Compound 4, a percentage reported as inhibition, at one concentration (the size of the read-out at that concentration, not a potency): 28.3%
Compound 4: the middle estimate sits 21.7 percentage points above what was measured; the measured number falls inside the stated range.
By their numbers in this assay, from the lowest: compound 3; then compound 4; then compound 1; then compound 2.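

In this assay a methoxy group on the phenyl ring brings a number 31.2 percentage points lower from compound 1 to compound 4 (beyond the scatter), so a group added to this ring can cost inhibition as well as add to it, which compound 2 alone could not show. Putting a six-membered carbon ring back in place of thiophen-3-yl is also not enough by itself: that change gives only a number 14.9 percentage points higher from compound 3 to compound 4 (beyond the scatter), while 2-methoxyphenyl in place of 4-formylphenyl gives a number 64.3 percentage points lower from compound 2 to compound 4 (beyond the scatter), so what the ring carries matters as much as the ring. Nothing available explains these shifts.

Still open, going by these compounds, is whether a methoxy on a different carbon of the ring would give a similar number. On these data alone, it is also open whether the gain seen with formyl is special to that group, which a carboxylic acid or an amine on the ring could help to test.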